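The compounds below may be only part of what the source reports. "The series", "measured", "known", "first", "only" and "open" are said of these compounds alone.

Three compounds share one core and differ only in what sits on a saturated ring carbon of the six-membered ring that carries the nitrogen. Compound 1 `COc1cc(COc2cc(N)c(Cl)cc2C(=O)CCCCN2CCCCC2)cc(OC)c1` carries hydrogen there, and in a functional assay for antagonist activity at 5-hydroxytryptamine receptor 4 (Rattus norvegicus) (a lower number here means a less potent compound, a higher number a more potent compound, by a factor of ten per unit of this negative logarithm), compound 1 gives 8.5. Compound 2 `COc1cc(COc2cc(N)c(Cl)cc2C(=O)CCCCN2CCC(C)CC2)cc(OC)c1` carries methyl, and in this assay compound 2 gives 8.3, a change of a number 0.20 log units lower from compound 1 to compound 2 (within the scatter). Compound 3 `CCCC1CCN(CCCCC(=O)c2cc(Cl)c(N)cc2OCc2cc(OC)cc(OC)c2)CC1` carries propyl, and in this assay compound 3 gives 7.7, the lowest of the three numbers, reached by a number 0.80 log units lower from compound 1 to compound 3 (beyond the scatter) and by a number 0.60 log units lower from compound 2 to compound 3 (beyond the scatter).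

Compound 4 `COc1cc(COc2cc(N)c(Cl)cc2C(=O)CCCCN2CCC(c3ccccc3)CC2)cc(OC)c1` is the next step: phenyl in place of propyl on a saturated ring carbon. Two of the measured steps bear on it. Going from hydrogen to methyl changed little, while lengthening to propyl lowered potency beyond the scatter, so a larger group at this place has so far cost activity. A phenyl group is larger still, but it is an aromatic ring rather than a chain, and nothing measured here shows how such a group behaves at this place. The expected outcome is therefore a step of about a number 0.10 log units lower from compound 3 to compound 4 (within the scatter), with wide uncertainty in either direction. For compound 4 the estimated value in this assay is 7.6, with a likely range from 6.8 to 8.4.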

Compound 4, negative logarithm of the antagonist equilibrium constant: 7.7
The estimate for compound 4 lay 0.10 log units below the measured number; the range from low to high includes it.
By their numbers in this assay, from the lowest: compounds 3 and 4 (each within the scatter of the next); then compounds 2 and 1 (each within the scatter of the next).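

In this assay, replacing propyl with phenyl at this place, three ring bonds from the ring nitrogen, brings in a six-membered aromatic ring and six heavy atoms in place of three, yet gives no change at the digits printed from compound 3 to compound 4 (within the scatter) and so shows that this place accepts an aromatic ring at the same level as the propyl chain. Compared with the smaller groups, phenyl gives a number 0.60 log units lower from compound 2 to compound 4 (beyond the scatter) and a number 0.80 log units lower from compound 1 to compound 4 (beyond the scatter) and thus sits as far from methyl and hydrogen as propyl does, so among these four compounds potency does not keep falling as the group gains heavy atoms, and compound 4 is the one that goes against the earlier downward run. Nothing supplied here explains why the chain and the aromatic ring land level.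

All the groups shown at this place are built from carbon and hydrogen alone, so it remains open how an amine, a hydroxyl group or a carboxylic acid would fare there. Also open, from the compounds shown here alone, is whether the level would hold for a benzyl group, a longer chain such as hexyl, or a phenyl ring carrying a methoxy group.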